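A few compounds are considered here, and "the series" means these few. Any claim that something is new, unique, unknown or untested is made for them only; others in the source may bear on it.

Working notes on the series, read in an ADME assay on HEK-293T cells (Homo sapiens) for cytotoxicity, read by luminescence, with a stated time of 24 h; on this read-out lower numbers stand for higher toxicity in this test and higher numbers for lower toxicity in this test. Compound 1 (`COc1ccc(Cn2c(C(=O)N3CCC(C(=O)NCc4ccccc4)CC3)cc3sccc32)cc1`) gives > 100000 nM, which is a limit and not a number. Compound 2 (`COc1ccc(Cn2c(C(=O)N3CCC(C(=O)NC(C)c4ccccc4)CC3)cc3sccc32)cc1`) gives > 100000 nM, also a limit and not a number, so it has no exact standing within the series. The evidence so far is the limit of > 100000 nM in this assay, at which 2 of the 2 values shown sit.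

Compound 3 (`COc1ccc(Cn2c(C(=O)N3CCC(C(=O)NCc4cccc(Br)c4)CC3)cc3sccc32)cc1`) carries 3-bromobenzyl in place of 1-phenylethyl on an amide-type nitrogen. Among the compounds with values here, the only measured step that bears on this change is a step that the two limits leave unreadable from compound 1 to compound 2, and it offers no size to carry over. No step beyond the scatter, and no direction, is therefore expected in this assay, and a further limit is the likeliest report. The expected step is a number no higher from compound 2 to compound 3 (the limit leaves the size open). The estimate for compound 3 is 100000 nM, with an expected range of 30000 nM to 150000 nM.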

Compound 3, half-maximal cytotoxic concentration: > 100000 nM
Compound 3 ended at the assay's limit; the forecaster's own chance of this, stated with the estimate: 80%; the middle value sits exactly at the limit.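

No new step can be read among compound 1, compound 2 and compound 3 in this assay, as each is reported only as a limit and not as a number: the limit of > 100000 nM in this assay, at which 3 of the 3 values shown sit.

The compounds shown leave open how far any of the three lies from that limit, and whether either change on the amide-type nitrogen alters the read-out at all.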